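The source may report more compounds than this note shows. Statements on the series, on what has been measured and on what is new or still open speak of the compounds shown alone.

Measured compounds:
Compound 1 `COc1cc(OC)c2c(=O)cc(-c3ccc(OCCF)cc3)oc2c1` gives 21% in a functional assay (Homo sapiens) for antiproliferative activity, read by resazurin assay, with a stated time of 48 h, tested at 20 uM; a lower number here means a weaker effect, a higher number a stronger effect of the compound at the concentration tested.
Compound 2 `COc1cc(OC)c2c(=O)cc(-c3ccc(Br)cc3)oc2c1` gives 22%.
Compound 3 `COc1cc(OC)c2c(=O)cc(-c3ccc(-c4ccc(F)nc4)cc3)oc2c1` gives 19%.

Compound 3 carries the lowest of the three numbers, but the steps of a number 2 percentage points lower from compound 1 to compound 3 (within the scatter) and a number 3 percentage points lower from compound 2 to compound 3 (within the scatter) both lie within the scatter, so no ranking among the three is supported. Compound 4 `COc1cc(OC)c2c(=O)cc(-c3ccc(NCCN4CCCC4)cc3)oc2c1` has not yet been measured; it differs from compound 3 in one place: (2-(pyrrolidin-1-yl)ethyl)amino in place of 6-fluoropyridin-3-yl on an aromatic carbon. The three measured steps, a number 1 percentage points higher from compound 1 to compound 2 (within the scatter), a number 2 percentage points lower from compound 1 to compound 3 (within the scatter) and a number 3 percentage points lower from compound 2 to compound 3 (within the scatter), all exchange the group at this same position and all stay within the scatter. On that basis the step of a number 2 percentage points higher from compound 3 to compound 4 (within the scatter) is expected to be small. Compound 4 is therefore estimated at 21%, within 5% to 42%.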

Compound 4, a percentage reported as inhibition, at one concentration (the size of the read-out at that concentration, not a potency): 80%
Estimate against measurement, compound 4: 59 percentage points below; the whole stated range lies below it.
By their numbers in this assay, from the lowest: compounds 3, 1 and 2 (each within the scatter of the next); then compound 4.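

At this position, on an aromatic carbon para to a large group, the choice of group can change the result in this assay: (2-(pyrrolidin-1-yl)ethyl)amino gives a number 61 percentage points higher from compound 3 to compound 4 (beyond the scatter), a number 58 percentage points higher from compound 2 to compound 4 (beyond the scatter) and a number 59 percentage points higher from compound 1 to compound 4 (beyond the scatter), whereas exchanges among 6-fluoropyridin-3-yl, bromo and 2-fluoroethoxy all stayed within the scatter. The data offer no explanation for this step. The compounds shown do not separate the contributions of the pyrrolidine ring, the ethyl chain and the amine hydrogen. As far as these compounds go, whether a morpholine ring, a dimethylamino group or a longer chain would give a similar number remains open.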